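The source may hold more compounds than are shown below. What is called first, only, known or untested is meant among the compounds shown, and "the series" means these compounds.

Compound 1 `O=C(NO)c1cccc(-c2cn([C@H]3C[C@@H](CO)N(CCCc4ccccc4)C3)nn2)c1` and compound 2 `O=C(NO)c1cccc(-c2cn([C@@H]3C[C@H](C(=O)O)N(CCCc4ccccc4)C3)nn2)c1` share one core and were both tested in an assay on Sf9 cells for inhibition of histone deacetylase 11 (Homo sapiens), read by fluorescence, tested at 0.5 uM; a lower number here means less inhibition, a higher number more inhibition at the concentration tested (going by the name of the read-out). Compound 1 returns only a limit of the assay, < 10%. Compound 2 also returns only a limit, < 10%. So compound 2 stands at the lowest reading the assay reports, the edge described by the limit of < 10% in this assay, at which 2 of the 2 values shown sit. Compound 3 `O=C(NO)c1cccc(-c2cn([C@H]3C[C@@H](C(=O)O)N(CCCc4ccccc4)C3)nn2)c1` is the mirror image of compound 2: the two compounds have the same atoms and bonds and differ only in configuration as drawn: 2 of 2 stereo elements differ (all stereocentres are inverted: mirror images); a stereocentre at a saturated ring carbon is drawn R in compound 2 and S in compound 3; a stereocentre at a saturated ring carbon is drawn R in compound 2 and S in compound 3. Within the data shown here, no measured step between compounds exists here, so in this assay no change beyond the scatter is expected. Compound 3 is expected to read 5%, from 0% to 15%. The expected step that the limit leaves unreadable from compound 2 to compound 3 lies within the scatter.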

Compound 3, a percentage reported as inhibition, at one concentration (the size of the read-out at that concentration, not a potency): < 10%
Compound 3: a limit, no number; the forecaster's own chance of this, stated with the estimate: 80%; the middle value is on the limit's open side.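

Compound 3 returns only a limit, so its steps from compound 1 and compound 2 cannot be read: the limit of < 10% in this assay, at which 3 of the 3 values shown sit.

In this assay the compounds shown leave open whether inverting the configuration, or carboxy in place of hydroxymethyl, changes the reading at all.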